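Dropping the methoxy group from a pyrazole-homopiperazine pair

The compounds below may be only part of what the source reports. "The series", "measured", "known", "first", "only" and "open" are said of these compounds alone.

Measured so far:
compound 1 `COc1cccc(-c2n[nH]cc2N2CCCNCC2)c1`: > 10000 nM
compound 2 `COc1ccc(-c2n[nH]cc2N2CCCNCC2)cc1`: > 10000 nM

Both compounds were tested in an assay on isolated protein for binding affinity to 5-hydroxytryptamine receptor 4 (Homo sapiens); on this read-out higher numbers stand for weaker inhibition and lower numbers for stronger inhibition. For compound 1 the result in this assay is > 10000 nM, which is a limit of the assay and not a number. For compound 2 the result in this assay is likewise > 10000 nM, again a limit rather than a number. Compound 2 therefore stands where every value shown stands: the limit of > 10000 nM in this assay, at which 2 of the 2 values shown sit. Within the data shown here, no step between measured compounds can be read from these two results, since neither is a number.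

Compound 3 `c1ccc(-c2n[nH]cc2N2CCCNCC2)cc1` differs from compound 2 in one place: hydrogen in place of methoxy on an aromatic carbon, on an aromatic carbon of a six-membered aromatic ring of carbon only. Since both measured values sit at the limit, no direction or size of a step is known here. Compound 2 and compound 1, which carry the methoxy at two different places, both reach only the limit. Compound 3 is expected to remain close to that limit in this assay, with an estimated value of 15000 nM, between 5000 nM and 50000 nM. The expected step is a step that the limit leaves unreadable from compound 2 to compound 3, not beyond the scatter.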

Compound 3, inhibition constant: > 10000 nM
Compound 3 ended at the assay's limit; the forecaster's own chance of this, stated with the estimate: 75%; the middle value lies beyond the limit too.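

In this assay compound 3 gives > 10000 nM, which is a limit of the assay and not a number. No new step can be read between compound 3 and either compound 1 or compound 2: the limit of > 10000 nM in this assay, at which 3 of the 3 values shown sit. The compounds shown leave open whether hydrogen or methoxy on the aromatic carbon makes any difference in this assay.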